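The source may report more compounds than this note shows. Statements on the series, on what has been measured and on what is new or still open speak of the compounds shown alone.

In a functional assay on CCRF-CEM cells (Homo sapiens) for cytotoxicity, with a stated time of 72 h (on this read-out higher numbers stand for weaker inhibition and lower numbers for stronger inhibition), compound 1 (`CCCc1ncnc2c1ncn2[C@@H]1O[C@H](CO)[C@@H](O)[C@H]1O`) gives 6800 nM and compound 2 (`CCCCc1ncnc2c1ncn2[C@@H]1O[C@H](CO)[C@@H](O)[C@H]1O`) gives 49000 nM as the higher of the two numbers, so compound 2 is the weaker inhibitor of this pair. Compound 3 (`CC(C)Cc1ncnc2c1ncn2[C@@H]1O[C@H](CO)[C@@H](O)[C@H]1O`) has not yet been measured. Its difference from compound 2 reads isopropyl in place of propyl on a saturated chain carbon bound to an aromatic carbon and, cut one bond further out, is butyl to isobutyl, with the same atoms joined differently. For the measured compounds named here, only one measured step bears on this change: a 7.2-fold higher number from compound 1 to compound 2 (0.86 log units; beyond the scatter) with a methyl added to the chain, a modest step that added an atom, whereas compound 3 merely rearranges the atoms of compound 2, so a smaller step toward a lower number is expected. No branched chain has been measured yet to test this. The expected step is a 2.5-fold lower number from compound 2 to compound 3 (0.39 log units; beyond the scatter) by this reasoning. The estimate for compound 3 is 20000 nM within an expected range of 6000 nM to 70000 nM as the likely span.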

Compound 3, half-maximal inhibitory concentration: > 130000 nM
Compound 3 gave a limit, no number; the forecaster's own chance of this, stated with the estimate: 15%; middle value at least 6.5-fold (0.81 log units) from the limit.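

In this assay compound 3 gives > 130000 nM, which is a limit of the assay and not a number. Even so, the arrangement of the chain matters at this position and not only its size: isopropyl in place of propyl, with the same atoms joined differently, gives an at least 2.6-fold higher number from compound 2 to compound 3 (0.42 log units; beyond the scatter). Adding the methyl to the inner chain carbon of the propyl group gives an at least 19-fold higher number from compound 1 to compound 3 (1.28 log units; beyond the scatter), a larger change than adding it further out, which gave a 7.2-fold higher number from compound 1 to compound 2 (0.86 log units; beyond the scatter).

As far as these compounds go, how far the true value of compound 3 lies past its limit remains open. So does whether a shorter chain such as ethyl, or a propyl chain ending in an amine, would give a lower number than compound 1.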